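A few compounds are considered here, and "the series" means these few. Any claim that something is new, unique, unknown or untested is made for them only; others in the source may bear on it.

In a functional assay on MCF7 cells (Homo sapiens) for antiproliferative activity (a lower number here means a stronger inhibitor, a higher number a weaker inhibitor), compound 1 `CSc1nc2c([nH]1)C(=O)C=C(Br)C2=O` gives 62.8 uM. Compound 2 `CN(C)C1=CC(=O)c2[nH]c(-c3ccccn3)nc2C1=O` returns only a limit of the assay in this assay, > 90 uM. Of the two values shown, compound 2 sits at the limit of > 90 uM in this assay, at which 1 of the 2 values shown sits. Compound 3 `O=C1C(Br)=CC(=O)c2[nH]c(-c3ccccn3)nc21` is not yet measured; it differs from compound 2 by bromo in place of dimethylamino on a double-bonded ring carbon. Going by the values given here, no measured pair shows this change directly, and compound 2 gives only a limit, so the size of the step stays uncertain. A move toward stronger inhibition beyond the scatter is expected in this assay, since compound 1 with bromo gives 62.8 uM. Compound 3 is estimated at 50 uM, with a range of 15 uM to 90 uM. This estimate implies an at least 1.8-fold lower number from compound 2 to compound 3 (0.25 log units; that floor lies within the scatter).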

Compound 3, concentration for 50% inhibition: > 90 uM
Compound 3: a limit, no number (the forecaster's own chance of this, stated with the estimate: 25%); middle value at least 1.8-fold (0.25 log units) from the limit.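

In this assay compound 3 gives only a limit of the assay, > 90 uM. Going by these compounds alone, with bromo held on the double-bonded ring carbon, pyridin-2-yl in place of methylsulfanyl on an aromatic carbon gives an at least 1.4-fold higher number from compound 1 to compound 3 (0.15 log units; that floor lies within the scatter), the first readable step. The step for bromo in place of dimethylamino cannot be read, and the values pile up at one limit: the limit of > 90 uM in this assay, at which 2 of the 3 values shown sit.

As far as these compounds go, whether any group on this double-bonded ring carbon gives a readable number alongside pyridin-2-yl stays open. A chloro group or a morpholine ring there would test this.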